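A few compounds are considered here, and "the series" means these few. Any claim that something is new, unique, unknown or untested is made for them only; others in the source may bear on it.

Measured so far:
compound 1 `Oc1cc(C(F)(F)F)ccc1-c1nc(-c2ccccc2O)n(-c2ccc(Cl)cc2)n1`: 87.3%
compound 2 `COc1ccc(-n2nc(-c3ccc(C(F)(F)F)cc3O)nc2-c2ccccc2O)cc1`: 86.6%

In a functional assay on PC-12 cells (Rattus norvegicus) for cytotoxicity, read by MTT assay, with stated times of 2 h and 24 h, tested at 5 uM (on this read-out lower numbers stand for a weaker effect and higher numbers for a stronger effect at the one concentration tested), compound 1 gives 87.3% and compound 2 gives 86.6%. Going by the values given here, compound 1 stands with compound 2 inside the scatter; the one measured step, a number 0.7 percentage points lower from compound 1 to compound 2 (within the scatter), changes a substituent on the aryl group at the aromatic nitrogen without moving the read-out. Compound 3 `Oc1cc(C(F)(F)F)ccc1-c1nc(-c2ccccc2O)n(-c2ccc(F)cc2F)n1` differs from compound 1 by 2,4-difluorophenyl in place of 4-chlorophenyl on an aromatic nitrogen, again a change on that aryl group. Among the compounds with values here, the only comparable step, a number 0.7 percentage points lower from compound 1 to compound 2 (within the scatter), is within the scatter, so no step beyond the scatter is expected, a number 0.3 percentage points lower from compound 1 to compound 3 (within the scatter). Compound 3 is therefore estimated at 87%, within 75% to 95%.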

Compound 3, a percentage reported as activity, at one concentration (the size of the read-out at that concentration, not a potency): 83.5%
Estimate against measurement, compound 3: 3.5 percentage points above; low and high end bracket the measured number.
By their numbers in this assay, from the lowest: compounds 3, 2 and 1 (each within the scatter of the next).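

At the aromatic nitrogen, replacing either one-substituent aryl group with 2,4-difluorophenyl gives no step beyond the scatter in this assay (a number 3.8 percentage points lower from compound 1 to compound 3 (within the scatter)) and (a number 3.1 percentage points lower from compound 2 to compound 3 (within the scatter)). The read-out thus holds across three aryl groups at this nitrogen, now including one that carries two substituents. No measurement of any property bears on this result.

Still open, going by these compounds, is whether an aryl group is needed at this nitrogen at all. An amine or a carboxylic acid on that ring, or a longer alkyl chain in its place, could show whether this position ever moves the read-out.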